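Methylsulfanyl for triazolyl on the pyridine amide of compound 1

The source may hold more compounds than are shown below. What is called first, only, known or untested is meant among the compounds shown, and "the series" means these compounds.

Measured so far:
compound 1 `COc1ccc(C(=O)N2C[C@H](Oc3nccc(C#N)c3C)CC[C@H]2C)c(-n2nccn2)n1` gives 3570 nM
compound 2 `CC(=O)Nc1cc(C(=O)N2C[C@H](Oc3nccc(C#N)c3C)CC[C@H]2C)c(-c2ccccc2)cn1` gives 10 nM

In an assay on cells for displacement of a labelled ligand from Orexin/Hypocretin receptor type 1 (Homo sapiens) (on this read-out lower numbers stand for stronger inhibition and higher numbers for weaker inhibition), compound 1 stands at the highest of the two numbers. Within the data shown here, its nearest neighbour is compound 2, whose number lies far below, beyond the scatter; the two share the core but differ in several places at once, so their values show only that compound 1 is the weaker of the pair.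

Compound 3 `COc1ccc(C(=O)N2C[C@H](Oc3nccc(C#N)c3C)CC[C@H]2C)c(SC)n1` is the next compound to be measured. Relative to compound 1 the change is methylsulfanyl in place of 2H-1,2,3-triazol-2-yl on an aromatic carbon, on an aromatic carbon of a six-membered aromatic ring with one nitrogen, next to the ring nitrogen. Among the measured compounds shown here, no measured pair isolates this change. With compound 1 already weak, the step is expected to be small, tending if anything toward a higher number, as a 1.4-fold higher number from compound 1 to compound 3 (0.15 log units; within the scatter). Compound 3 is therefore expected to give about 5000 nM, within the range 1000 nM to 25000 nM.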

Compound 3, inhibition constant: 2520 nM
Estimate against measurement, compound 3: 2.0-fold (0.30 log units) above, and the stated range covers the measured number.
By their numbers in this assay, from the lowest: compound 2; then compounds 3 and 1 (each within the scatter of the next).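

In this assay, methylsulfanyl in place of 2H-1,2,3-triazol-2-yl, next to the ring nitrogen, gives a 1.4-fold lower number from compound 1 to compound 3 (0.15 log units; within the scatter) on an otherwise unchanged structure. This read-out therefore does not separate the two groups at this position, even though the entering group has no ring and fewer heavy atoms. Nothing available bears on why the two groups read alike.

Compound 2 gives 10 nM but differs from compound 1 in several places, so the compounds shown do not tell which of those differences accounts for the gap. Also open, on these data alone, is how an amine or a carboxylic acid would read at this same position on the core of compound 1, and whether any group there can move the number beyond the scatter.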